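A few compounds are considered here, and "the series" means these few. Any claim that something is new, unique, unknown or untested is made for them only; others in the source may bear on it.

Of the compounds shown here, two anchor the series so far. In a functional assay on NCI-H929 cells (Homo sapiens) for antiproliferative activity, with a stated time of 24 h (a lower number here means a stronger inhibitor, a higher number a weaker inhibitor), compound 1 (`COc1ccc(F)cc1-c1ccnc2[nH]c(C3=CCC(C(=O)O)CC3)cc12`) gives 1200 nM as its half-maximal inhibitory concentration, and compound 2 (`COc1ccc(F)cc1-c1c(F)cnc2[nH]c(C3=CCN([C@H]4CC[C@@H](C(=O)O)CC4)CC3)cc12`) gives 35 nM as the lower of the two numbers, a gap beyond the scatter. These two compounds differ in more than one place, so the gap cannot be assigned to any single change.

Compound 3 (`COc1ccc(F)cc1-c1c(F)cnc2[nH]c(C3=CCN([C@H]4CC[C@H](C(=O)O)CC4)CC3)cc12`) is to be read against compound 2. The structural change (the two compounds have the same atoms and bonds and differ only in configuration as drawn: 2 of 2 stereo elements differ (all stereocentres are inverted: mirror images); a stereocentre at a saturated ring carbon is drawn s in compound 2 and r in compound 3; a stereocentre at a saturated ring carbon is drawn s in compound 2 and r in compound 3) removes nothing and adds nothing: the atoms and bonds are the same, and only the configuration as drawn differs at the two saturated ring carbons.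

Within the data shown here, no measured pair shows what such an inversion does, so the expectation rests on compound 2 at 35 nM alone. In this assay a moderate step toward a higher number, meaning a weaker inhibitor, is expected, and it may not clear the scatter by much. The estimated step (a 2.3-fold higher number from compound 2 to compound 3 (0.36 log units; beyond the scatter)) remains provisional. For compound 3 the expected value is 80 nM within an estimated range of 25 nM to 350 nM until a measurement is available.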

Compound 3, half-maximal inhibitory concentration: 40 nM
Compound 3: the middle estimate sits 2.0-fold (0.30 log units) above what was measured; measured number inside the range.
By their numbers in this assay, from the lowest: compounds 2 and 3 (each within the scatter of the next); then compound 1.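

Inverting both stereocentres at the saturated ring carbons gives, in this assay, a 1.1-fold higher number from compound 2 to compound 3 (0.06 log units; within the scatter), and this is the first step in the series that can be assigned to a single change. The read-out therefore does not separate the two configurations as drawn, at least for this pair, which carries the carboxylic acid and the fluorine on the shared core. The reading is clean with respect to the structure, with no atom or bond entering or leaving, so any contribution from other groups is excluded from this step: the fact that compounds 2 and 3 differ only in the configuration as drawn

Which of the several structural differences between compound 1 and the pair of compound 2 and compound 3 accounts for the gap in their numbers stays open, as no single-change step connects them. Also open, on these data alone, is whether configuration remains equally silent when the carboxylic acid is replaced by another group, such as a primary amide, or whether this pair's result is particular to the acid.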